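The compounds below may be only part of what the source reports. "The series", "measured", "known", "first", "only" and "open" are said of these compounds alone.

In a functional assay on MCF-10A cells (Homo sapiens) for antiproliferative activity, with a stated time of 48 h (on this read-out lower numbers stand for an effect already at smaller amounts and higher numbers for an effect only at larger amounts of compound), three compounds share one core and differ in a single group on an aromatic carbon. Compound 1 `COc1ccc2nc(C)cc(NCc3ccc(C)cc3)c2c1`, carrying methyl, gives 18800 nM. Compound 2 `COc1ccc2nc(C)cc(NCc3ccc(C(C)(C)C)cc3)c2c1`, carrying tert-butyl, gives 6900 nM, and compound 3 `COc1ccc2nc(C)cc(NCc3ccc(C(F)(F)F)cc3)c2c1`, carrying trifluoromethyl, gives 7600 nM. Compound 3 therefore sits level with compound 2, as the numbers show a 1.1-fold higher number from compound 2 to compound 3 (0.04 log units; within the scatter), and clearly apart from the methyl compound, with a 2.5-fold lower number from compound 1 to compound 3 (0.39 log units; beyond the scatter).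

Compound 4 `COc1ccc(CNc2cc(C)nc3ccc(OC)cc23)cc1` differs from compound 3 in one place, with methoxy in place of trifluoromethyl on an aromatic carbon, para to a large group: methoxy in place of trifluoromethyl on an aromatic carbon. Within the data shown here, no measured step involves methoxy, so the evidence is indirect. The other swaps at this place are the guide: a 2.7-fold lower number from compound 1 to compound 2 (0.44 log units; beyond the scatter) and a 2.5-fold lower number from compound 1 to compound 3 (0.39 log units; beyond the scatter) are both modest, and the swap between the two larger groups stays within the scatter. Large jumps therefore seem unlikely. The entering group is smaller than the one leaving, and compound 1, with its small methyl, gives 18800 nM, so a small move towards a higher number is the more likely outcome in this assay. The expected change is a 1.6-fold higher number from compound 3 to compound 4 (0.20 log units; within the scatter). For compound 4 the estimated value is 12000 nM, with an expected range from 5500 nM to 25000 nM.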

Compound 4, half-maximal effective concentration: 7000 nM
Estimate against measurement, compound 4: 1.7-fold (0.23 log units) above, within the range that was stated.
By their numbers in this assay, from the lowest: compounds 2, 4 and 3 (each within the scatter of the next); then compound 1.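

In this assay, swapping trifluoromethyl for methoxy changes the group at this place, on an aromatic carbon para to a large group, from 4 heavy atoms and no hydrogen-bond acceptor to 2 heavy atoms and 1 hydrogen-bond acceptor, yet the result is a 1.1-fold lower number from compound 3 to compound 4 (0.04 log units; within the scatter) and so shows no real shift. The comparison with the other large group agrees, with a 1.0-fold higher number from compound 2 to compound 4 (0.01 log units; within the scatter) also inside the scatter, which makes methoxy the third group in a level set with tert-butyl and trifluoromethyl. Only methyl stands apart among these four compounds, as a 2.7-fold lower number from compound 1 to compound 4 (0.43 log units; beyond the scatter) shows, so a lower count of heavy atoms in the entering group does not by itself bring the number towards that of compound 1.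

No measurement in this set explains why methyl differs from the other three groups or why those three sit level. Also open, going by these compounds, is how this place responds to a group of another kind, such as an amine, a carboxylic acid or a longer chain like butoxy, and whether any of them would move the number beyond the scatter of this level set.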